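From 4-methoxyphenyl to furan-3-yl on a shared core

The source may report more compounds than this note shows. Statements on the series, on what has been measured and on what is new or still open speak of the compounds shown alone.

In an ADME assay on Vero cells (Chlorocebus sabaeus) for cytotoxicity, read by MTT assay, with a stated time of 96 h (on this read-out higher numbers stand for lower toxicity in this test and lower numbers for higher toxicity in this test), compound 1 (`CC(=O)c1ccc2c(c1)nc(-c1ccoc1)n2C1CCCCC1`) gives 80000 nM and compound 2 (`COc1ccc(-c2nc3cc(/C(C)=N/NC(N)=S)ccc3n2C2CCCCC2)cc1`) gives 40000 nM as its value. These two numbers lie within the usual scatter of each other, so compound 2 stands level with compound 1 on the data so far. For the measured compounds named here, the two compounds differ in more than one place, and no measured pair yet isolates a single change.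

Compound 3 (`C/C(=N\NC(N)=S)c1ccc2c(c1)nc(-c1ccoc1)n2C1CCCCC1`) differs from compound 2 in one place: furan-3-yl in place of 4-methoxyphenyl on an aromatic carbon, next to the ring atom that bears a cyclohexyl group (furan-3-yl in place of 4-methoxyphenyl on an aromatic carbon). Compound 1 already carries furan-3-yl and sits at 80000 nM in this assay without leaving the scatter of compound 2, which carries 4-methoxyphenyl. On that slim evidence no shift beyond the scatter is expected, in either direction. The expected size of the change, a 1.1-fold higher number from compound 2 to compound 3 (0.05 log units; within the scatter) in this assay, is therefore small. Compound 3 is estimated at 45000 nM with an expected range from 18000 nM to 100000 nM in this assay.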

Compound 3, half-maximal cytotoxic concentration: 25000 nM
Compound 3: the middle estimate sits 1.8-fold (0.26 log units) above what was measured; the measured number falls inside the stated range.
By their numbers in this assay, from the lowest: compounds 3, 2 and 1 (each within the scatter of the next, the first and the last beyond it).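

In this assay, the change on the aromatic carbon between two ring nitrogen atoms can now be read alone: furan-3-yl in place of 4-methoxyphenyl gives a 1.6-fold lower number from compound 2 to compound 3 (0.20 log units; within the scatter), so this exchange of one aromatic ring for another does not move the read-out beyond the scatter. For the compounds shown here, the other change on the shared core, on the aromatic carbon that carries a group of 3 heavy atoms in compound 1 and a group of 7 heavy atoms in compound 3, gives a 3.2-fold lower number from compound 1 to compound 3 (0.51 log units; beyond the scatter), the only step so far that lies beyond the scatter, and a modest one. Nothing available explains either step.

On these data alone, each of these two changes rests on a single pair, so it stays open whether the group of 7 heavy atoms would give a similar step with 4-methoxyphenyl in place of furan-3-yl, and how a plain phenyl, a pyridine ring or an amine would read at the position between two ring nitrogen atoms. As far as these compounds go, the cyclohexyl group is common to all three compounds, so what a methyl group or a longer chain would do in its place also remains open.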